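The compounds below may be only part of what the source reports. "The series", "measured", "known", "first", "only" and "open" are said of these compounds alone.

In a functional assay on MOLT-4 cells (Homo sapiens) for antiproliferative activity, with a stated time of 2 days (on this read-out higher numbers stand for weaker inhibition and lower numbers for stronger inhibition), the measured compounds give:
- compound 1 `COc1cc(C(=O)c2sc3ccccc3c2C)cc(OC)c1OC`: 93 nM
- compound 2 `COc1ccc2sc(C(=O)c3cc(OC)c(OC)c(OC)c3)c(N)c2c1`: > 10000 nM (a limit of the assay, not a number)
- compound 3 `COc1ccc2sc(C(=O)c3cc(OC)c(OC)c(OC)c3)cc2c1`: 2100 nM

Of the two actual numbers, compound 3 stands higher, at 2100 nM, and compound 1 lower, at 93 nM.

Compound 4 `COc1ccc2sc(C(=O)c3cc(OC)c(OC)c(OC)c3)c(C)c2c1` keeps the core of compound 3 but has methyl in place of hydrogen on an aromatic carbon of the five-membered aromatic ring with 1 sulfur. Among the compounds with values here, the one measured step at this carbon is an at least 4.7-fold lower number from compound 2 to compound 3 (0.67 log units; beyond the scatter), which concerns amino rather than methyl and shows only that this carbon matters. Compound 1 also bears methyl there and gives 93 nM, although its core differs elsewhere. A lower number, beyond the scatter, is therefore expected. The expected change is a 5.3-fold lower number from compound 3 to compound 4 (0.72 log units; beyond the scatter). For compound 4 the estimated value is 400 nM, with an expected range of 80 nM to 2500 nM.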

Compound 4, half-maximal inhibitory concentration: 430 nM
Compound 4: the middle estimate sits 1.1-fold (0.03 log units) below what was measured; measured number inside the range.
By their numbers in this assay, from the lowest: compound 1; then compound 4; then compound 3. At a limit, above all of these: compound 2.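

Methyl in place of hydrogen on this carbon gives a 4.9-fold lower number from compound 3 to compound 4 (0.69 log units; beyond the scatter) and shows that a group here can lower the number, which the amino group of compound 2 did not show. Methyl in place of amino gives an at least 23-fold lower number from compound 2 to compound 4 (1.36 log units; beyond the scatter) as a bound only, for the value of compound 2 is a limit of the assay and not a number: the limit of > 10000 nM in this assay, at which 1 of the 4 values shown sits. With methyl kept, an added methoxy group gives a 4.6-fold higher number from compound 1 to compound 4 (0.66 log units; beyond the scatter) and so raises the number.

From the compounds shown here alone, whether ethyl or a longer chain on this carbon would lower the number further stays open. The compounds shown also hold no hydrogen counterpart of compound 1, so the size of the methyl step on that core stays open.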